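A few compounds are considered here, and "the series" means these few. Any claim that something is new, unique, unknown or untested is made for them only; others in the source may bear on it.

Going by the values given here, compound 1 `O=C(COc1ccc(C(=O)/C=C/c2cccc(Cl)c2)cc1)N[C@H]1CCOC1=O` is the only member of this small set that returns a number in a functional assay on PC-3 cells (Homo sapiens) for antiproliferative activity, read by MTT assay, with a stated time of 72 h; a higher number here means a weaker inhibitor, a lower number a stronger inhibitor: compound 1 gives 4990 nM. Compound 2 `Cc1ccc(C(C)C)c(OCCSC(=S)N[C@H]2CCOC2=O)c1` reaches only a limit in this assay, > 64000 nM. Compound 3 `O=C1OCC[C@@H]1NC(=S)SCCOc1ccccc1Cc1ccccc1` likewise stops at a limit in this assay, > 64000 nM. Among the compounds with values here, the set is thus dominated by the limit of > 64000 nM in this assay, at which 2 of the 3 values shown sit, and no measured step between two compounds differing in a single place is available to calibrate the change under study. Compound 4 `O=C(COc1ccc(C(=O)/C=C/c2ccc(F)cc2)cc1)N[C@H]1CCOC1=O` carries 4-fluorophenyl in place of 3-chlorophenyl on a double-bonded chain carbon bound to a double-bonded chain carbon. Within the data shown here, with no comparable measured step in hand, this exchange of one halogen-bearing aromatic ring for another is expected to move the half-maximal inhibitory concentration little, if at all, beyond the usual scatter, with a slight lean toward weaker inhibition. The step from compound 1 to compound 4 is expected to be a 1.3-fold higher number from compound 1 to compound 4 (0.11 log units; within the scatter). Compound 4 is therefore estimated at 6500 nM, within a range from 2000 nM to 22000 nM.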

Compound 4, half-maximal inhibitory concentration: 15600 nM
Beside the measured number, compound 4's estimate is 2.4-fold (0.38 log units) below it; low and high end bracket the measured number.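

In this assay, going by these compounds alone, 4-fluorophenyl in place of 3-chlorophenyl on a double-bonded chain carbon bound to a double-bonded chain carbon gives the first measured step of this set: a 3.1-fold higher number from compound 1 to compound 4 (0.50 log units; beyond the scatter). The position is therefore not indifferent to which halogen-bearing aromatic ring it carries, although the step is only modest. Compound 4 also still returns a number rather than a limit, so this change weakens the compound without taking it out of the measurable range.

Within the data shown here, the single step cannot separate the change of halogen from the change of its place on the ring, and 4-chlorophenyl, 3-fluorophenyl or plain phenyl would be needed to tell these apart. The wider set offers little further calibration, since it still rests heavily on a limit of the assay: the limit of > 64000 nM in this assay, at which 2 of the 4 values shown sit.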